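Working notes: halogenated phenyl swaps in one series

The source may report more compounds than this note shows. Statements on the series, on what has been measured and on what is new or still open speak of the compounds shown alone.

Measured in a functional assay on MIA PaCa-2 cells (Homo sapiens) for inhibition, read by MTT assay, with a stated time of 48 h, tested at 10 uM; on this read-out lower numbers stand for less inhibition of growth and higher numbers for more inhibition of growth at the one concentration tested:
- compound 1 `Cc1oc2c([C@H]3CCN(C)C[C@H]3O)c(O)cc(O)c2c(=O)c1C(O)c1ccc(Cl)cc1`: 15%
- compound 2 `Cc1oc2c([C@H]3CCN(C)C[C@H]3O)c(O)cc(O)c2c(=O)c1C(O)c1cccc(Cl)c1`: 2%
- compound 3 `Cc1oc2c([C@H]3CCN(C)C[C@H]3O)c(O)cc(O)c2c(=O)c1C(O)c1ccc(F)c(Br)c1`: 9%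

Compound 3 lies within the scatter of both neighbours, with a number 6 percentage points lower from compound 1 to compound 3 (within the scatter) and a number 7 percentage points higher from compound 2 to compound 3 (within the scatter). Compound 4 `Cc1oc2c([C@H]3CCN(C)C[C@H]3O)c(O)cc(O)c2c(=O)c1C(O)c1c(Cl)cccc1Cl` carries 2,6-dichlorophenyl in place of 3-bromo-4-fluorophenyl on a saturated chain carbon bound to an aromatic carbon and an oxygen on a saturated carbon. Among the measured compounds shown here, no measured compound tests this group. The nearest evidence is the three swaps at the same place, and the largest is modest, a number 13 percentage points lower from compound 1 to compound 2 (beyond the scatter). No direction can be argued from them, so no change beyond the scatter is expected. The expected step is a number 1 percentage points lower from compound 3 to compound 4 (within the scatter). For compound 4 the estimated value is 8%, with an expected range of 0% to 20%.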

Compound 4, percent growth inhibition at one concentration: 0%
Estimate against measurement, compound 4: 8 percentage points above, within the range that was stated.
By their numbers in this assay, from the lowest: compounds 4, 2, 3 and 1 (each within the scatter of the next, the first and the last beyond it).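

Replacing the other groups with 2,6-dichlorophenyl at this place gives a number 9 percentage points lower from compound 3 to compound 4 (within the scatter) and also a number 2 percentage points lower from compound 2 to compound 4 (within the scatter) so the new group does not separate from 3-bromo-4-fluorophenyl or 3-chlorophenyl. Against 4-chlorophenyl it gives a number 15 percentage points lower from compound 1 to compound 4 (beyond the scatter) which makes compound 4 the second compound beyond the scatter of compound 1, while compound 3 remains within it. No evidence on the cause of these steps is available.

Whether any group here can lift growth inhibition well above that of compound 1 stays open, since only halogenated phenyl groups are shown. An unsubstituted phenyl or a phenyl bearing an amine or a carboxylic acid could show whether the halogens matter at all.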